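Thiocarbamate series: acid dissociation with a changed aryl linker

The source may report more compounds than this note shows. Statements on the series, on what has been measured and on what is new or still open speak of the compounds shown alone.

compound 1 `O=[N+]([O-])c1ccc(Oc2ccc(NC(=S)Oc3ccc(O)cc3)cc2)cc1`: 9.23
compound 2 `CC(=O)Nc1ccc(OC(=S)Nc2ccc(Sc3ccc([N+](=O)[O-])cc3)cc2)cc1`: 8.99

In a physicochemical assay for acid dissociation, compound 1 gives 9.23 and compound 2 gives 8.99. Compound 2 holds the lower of the two numbers, but its gap to compound 1 lies within the scatter, so the two cannot be ordered against each other. Compound 3 `CC(=O)Nc1ccc(OC(=S)Nc2ccc(Oc3ccc([N+](=O)[O-])cc3)cc2)cc1` has not yet been measured. The change from compound 2 to compound 3 is 4-nitrophenoxy in place of (4-nitrophenyl)sulfanyl on an aromatic carbon. Among the compounds with values here, no measured pair shows this kind of change, so there is no step to draw on. Since the thiocarbamate and acetamide ends are kept as they are, the expected step in this assay is a number 0.06 log units higher from compound 2 to compound 3 (within the scatter), a small move that should stay within the scatter. For compound 3 the estimate in this assay is 9.05, with a range from 8.7 to 9.4.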

Compound 3, acid dissociation constant: 9.04
The estimate for compound 3 lay 0.01 log units above the measured number; measured number inside the range.
By their numbers in this assay, from the lowest: compounds 2, 3 and 1 (each within the scatter of the next).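

In this assay, the exchange of (4-nitrophenyl)sulfanyl for 4-nitrophenoxy on an aromatic carbon, para to a large group, now has a measured step, a number 0.05 log units higher from compound 2 to compound 3 (within the scatter), so this change of linking atom leaves the read-out within the scatter. The same compound also gives the series its first reading at the other end, where acetamido stands in place of hydroxy on an aromatic carbon, with a number 0.19 log units lower from compound 1 to compound 3 (within the scatter), so neither single change separates its pair. No measurement available here speaks to the reason for either step.

From the compounds shown here alone, whether an amine or a carboxylic acid in place of acetamido would give a step beyond the scatter remains open. So does the outcome of a methylene link in place of the oxygen or sulfur, and of a group other than nitro on the far ring.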